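Methoxy on the Phenyl Ring: Estimating Compound 4

This account rests on a few compounds, and the source may have more. Where it says the series, first, only, none or still open, it means among the compounds named here.

Compound 1, `O=c1oc2ccccc2cc1-c1cn2nc(-c3c([O-])[o+]nn3-c3ccccc3)sc2n1`, gives 6.3 ug/mL in a functional assay on HT-29 cells (Homo sapiens) for cytotoxicity, read by sulforhodamine B assay; a higher number here means a weaker inhibitor of growth, a lower number a stronger inhibitor of growth.
Compound 2, `O=c1oc2ccccc2cc1-c1cn2nc(-c3c([O-])[o+]nn3-c3ccc(Cl)cc3)sc2n1`, gives 4 ug/mL in this assay.
Compound 3, `O=c1oc2ccc(Cl)cc2cc1-c1cn2nc(-c3c([O-])[o+]nn3-c3ccccc3)sc2n1`, gives 7.7 ug/mL in this assay.

Compound 3 has the highest of the three numbers, but its gap to compound 1 and to compound 2 lies within the scatter, so the three compounds are indistinguishable in this assay. Compound 4, `COc1ccc(-n2n[o+]c([O-])c2-c2nn3cc(-c4cc5cc(Cl)ccc5oc4=O)nc3s2)cc1`, differs from compound 3 by methoxy in place of hydrogen on an aromatic carbon. The closest measured precedent is the change on the same phenyl ring, a 1.6-fold lower number from compound 1 to compound 2 (0.20 log units; within the scatter), a chloro step that did not leave the scatter; the change on the other ring, a 1.2-fold higher number from compound 1 to compound 3 (0.09 log units; within the scatter), was likewise flat. Among the measured compounds shown here, no measured step involves a methoxy group, so nothing indicates that compound 4 should move beyond the scatter in this assay. Compound 4 is therefore expected to give about 6.5 ug/mL, a step of a 1.2-fold lower number from compound 3 to compound 4 (0.07 log units; within the scatter). The estimated range for compound 4 runs from 3.5 ug/mL to 12 ug/mL.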

Compound 4, concentration for 50% growth inhibition: 3.68 ug/mL
Compound 4: middle estimate off by 1.8-fold (0.25 log units), on the high side; the range from low to high includes it.
By their numbers in this assay, from the lowest: compounds 4, 2, 1 and 3 (each within the scatter of the next, the first and the last beyond it).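

In this assay, the change from phenyl to 4-methoxyphenyl gives a 2.1-fold lower number from compound 3 to compound 4 (0.32 log units; beyond the scatter) and is the only step shown that leaves the scatter, although only modestly. On this same ring, chloro in place of hydrogen gave a 1.6-fold lower number from compound 1 to compound 2 (0.20 log units; within the scatter) and stayed within the scatter, so this position is the one place in the set where a substituent has been seen to shift the number at all. No measurement here offers an explanation for the step.

The compounds shown leave open whether methoxy would produce a step beyond the scatter on compound 1, which lacks the chloro carried by compound 3. They also leave open whether a hydroxy group, an amine or a longer chain such as ethoxy, placed on the same ring carbon, would lower the number further or raise it again.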